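The compounds below may be only part of what the source reports. "The series", "measured", "known", "first", "only" and "open" are said of these compounds alone.

Compound 2 `CCCCc1nc(=O)c(S(=O)(=O)c2ccc(-n3ccccc3=O)cc2)c(O)n1-c1c(OC)cccc1OC` stands lowest of the two numbers measured in an ADME assay on microsomes from liver (Mus musculus) for metabolic stability, using NADPH, with a stated time of 10 min (on this read-out higher numbers stand for a more stable compound and lower numbers for a less stable compound), giving 63%. Compound 1 `CCCCc1nc(=O)c(S(=O)(=O)c2ccc(-c3ccnc(NC(=O)C4CC4)c3)cc2)c(O)n1-c1c(OC)cccc1OC` gives 72% in this assay. Among the measured compounds shown here, the only measured step, a number 9 percentage points lower from compound 1 to compound 2 (within the scatter), concerns an exchange of a different group. Compound 3 `CCCCc1nc(=O)c(S(=O)(=O)c2ccc(-n3cc(Cl)ccc3=O)cc2)c(O)n1-c1c(OC)cccc1OC` differs from compound 2 by chloro in place of hydrogen on an aromatic carbon. For the measured compounds named here, no measured step involves a chloro entering at this place, so nothing here points to a change beyond the scatter. Compound 3 is therefore expected to show no change at the digits printed from compound 2 to compound 3 (within the scatter). In this assay compound 3 is estimated at 63%, with a range from 45% to 80%.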

Compound 3, percent of the compound remaining: 100%
Beside the measured number, compound 3's estimate is 37 percentage points below it; the whole stated range lies below it.
By their numbers in this assay, from the lowest: compounds 2 and 1 (each within the scatter of the next); then compound 3.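

In this assay, among the compounds shown here, chloro on this aromatic carbon, two atoms from the ring nitrogen, goes with a number 37 percentage points higher from compound 2 to compound 3 (beyond the scatter), so this position can move the read-out well past the scatter, which the only earlier step did not do. The same chloro also lifts the smaller group clear of the larger group of compound 1, with a number 28 percentage points higher from compound 1 to compound 3 (beyond the scatter). Nothing given here accounts for this result. From the compounds shown here alone, whether the step belongs to chloro itself or to any group at this place stays open. A fluoro or a methyl at this carbon would separate the two.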